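The compounds below may be only part of what the source reports. "The series", "measured", "known", "first", "only" and "open" are said of these compounds alone.

Compound 1 `COc1ccc(/C=C/C(=O)c2cccc(NC(=O)c3cc(-c4ccncc4)n[nH]3)c2)cc1`: 38400 nM
Compound 2 `O=C(/C=C/c1ccc([N+](=O)[O-])cc1)c1cccc(NC(=O)c2cc(-c3ccncc3)n[nH]2)c1`: 52800 nM
Compound 3 `COc1ccccc1/C=C/C(=O)c1cccc(NC(=O)c2cc(-c3ccncc3)n[nH]2)c1`: 41700 nM

In a functional assay, read by spectrophotometry, tested at 100 uM (on this read-out lower numbers stand for stronger inhibition and higher numbers for weaker inhibition), compound 1 gives 38400 nM, which cannot be told apart from the values of the other two measured compounds. Compound 4 `O=C(/C=C/c1ccc(Cl)cc1Cl)c1cccc(NC(=O)c2cc(-c3ccncc3)n[nH]2)c1` makes one structural change to compound 1: 2,4-dichlorophenyl in place of 4-methoxyphenyl on a double-bonded chain carbon bound to a double-bonded chain carbon. Two measured steps alter the aromatic group at this same place: a 1.4-fold higher number from compound 1 to compound 2 (0.14 log units; within the scatter), and a 1.1-fold higher number from compound 1 to compound 3 (0.04 log units; within the scatter). The remaining step, a 1.3-fold lower number from compound 2 to compound 3 (0.10 log units; within the scatter), is just as small. Among the compounds with values here, no measured compound carries 2,4-dichlorophenyl, so this group itself is untested. A change beyond the scatter is therefore not expected, and the estimated step is a 1.0-fold higher number from compound 1 to compound 4 (0.02 log units; within the scatter). In this assay the estimate for compound 4 is 40000 nM, with the value expected between 20000 nM and 75000 nM.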

Compound 4, half-maximal inhibitory concentration: 35000 nM
For compound 4 the middle estimate is 1.1-fold (0.06 log units) above the measured one; low and high end bracket the measured number.
By their numbers in this assay, from the lowest: compounds 4, 1, 3 and 2 (each within the scatter of the next).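

In this assay a ring carrying two chlorines behaves like the methoxy and nitro rings at this place on the double-bonded chain carbon: the steps are a 1.1-fold lower number from compound 1 to compound 4 (0.04 log units; within the scatter) and a 1.2-fold lower number from compound 3 to compound 4 (0.08 log units; within the scatter) and a 1.5-fold lower number from compound 2 to compound 4 (0.18 log units; within the scatter). All four aromatic groups shown now give numbers within the scatter of each other, whether the ring carries one substituent or two. Nothing shown gives a reason for this flat result. As far as these compounds go, it remains open whether the number moves with a group of another kind here, such as a carboxylic acid on the ring, an amine on the ring or a cyclohexyl ring replacing the phenyl.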